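A Methoxy Group Added to Compound 1

The source may hold more compounds than are shown below. What is called first, only, known or untested is meant among the compounds shown, and "the series" means these compounds.

For the measured compounds named here, in a functional assay on HepG2 cells (Homo sapiens) for inhibition, read by MTT assay, with a stated time of 72 h (a higher number here means a weaker inhibitor, a lower number a stronger inhibitor), compound 1 `O=C(Nc1ccccc1)C1CCN(C/C=C/c2ccccc2)CC1` gives 90900 nM, the highest of the three numbers measured so far. Compound 2 `CCc1ccc(NC(=O)C2CCN(C/C=C/c3ccccc3)CC2)cc1` gives 23300 nM, and compound 3 `CC(C)c1ccc(NC(=O)C2CCN(C/C=C/c3ccccc3)CC2)cc1` gives 12200 nM. Compound 4 `COc1cccc(NC(=O)C2CCN(C/C=C/c3ccccc3)CC2)c1` has methoxy in place of hydrogen on an aromatic carbon, meta to a large group (methoxy in place of hydrogen on an aromatic carbon). The closest evidence comes from adding ethyl, a 3.9-fold lower number from compound 1 to compound 2 (0.59 log units; beyond the scatter), and isopropyl, a 7.5-fold lower number from compound 1 to compound 3 (0.87 log units; beyond the scatter). Both modest steps go beyond the scatter, while the further change, a 1.9-fold lower number from compound 2 to compound 3 (0.28 log units; within the scatter), stays within it. Going by the values given here, no measured compound carries methoxy, so this guide is loose. In this assay, the expected step is a modest one towards a lower number, a 2.0-fold lower number from compound 1 to compound 4 (0.31 log units; beyond the scatter). For compound 4, the estimated value is 45000 nM, with an expected range of 15000 nM to 110000 nM.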

Compound 4, half-maximal inhibitory concentration: 78600 nM
The estimate for compound 4 lay 1.7-fold (0.24 log units) below the measured number; measured number inside the range.
By their numbers in this assay, from the lowest: compounds 3 and 2 (each within the scatter of the next); then compounds 4 and 1 (each within the scatter of the next).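

In this assay the step with methoxy on this aromatic carbon, meta to a large group, is a 1.2-fold lower number from compound 1 to compound 4 (0.06 log units; within the scatter) and so cannot be told apart from no change, unlike the steps with ethyl and isopropyl. Compound 4 also stands apart from the other two substituted compounds, with a 3.4-fold higher number from compound 2 to compound 4 (0.53 log units; beyond the scatter) and a 6.4-fold higher number from compound 3 to compound 4 (0.81 log units; beyond the scatter) as the steps to it. No measurement shown here accounts for this gap.

Compounds 2 and 3 differ from compound 4 in both the group and its place, so these two effects remain unseparated. Going by these compounds, how an amine or a hydroxyl group would behave in place of methoxy also remains open.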